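The source may hold more compounds than are shown below. What is called first, only, known or untested is meant among the compounds shown, and "the series" means these compounds.

Values in a functional assay on MDA-MB-231 cells (Homo sapiens) for antiproliferative activity, read by MTT assay, with a stated time of 24 h (a higher number here means a weaker inhibitor, a lower number a stronger inhibitor), follow.
Compound 1 `COc1ccc(-c2noc(-c3ccccc3)n2)cc1OC1CCCC1` gives > 1000000 nM (a limit of the assay)
Compound 2 `COc1ccc(-c2noc(-c3ccc(F)cc3)n2)cc1OC1CCCC1` gives 55500 nM (a measured number)
Compound 3 `COc1ccc(-c2noc(-c3ccc(O)cc3)n2)cc1OC1CCCC1` gives 310 nM (a measured number)

The entry for compound 1 is a limit and not a number. Of the two true numbers, compound 2 holds the higher, and the gap is large (a 180-fold lower number from compound 2 to compound 3 (2.25 log units; beyond the scatter)).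

Compound 4 `COc1ccc(-c2noc(-c3ccc(F)cc3)n2)cc1O` differs from compound 2 by hydrogen in place of cyclopentyl on an oxygen on an aromatic ring. The other steps measured here were also large (an at least 18-fold lower number from compound 1 to compound 2 (1.25 log units; beyond the scatter) and an at least 3200-fold lower number from compound 1 to compound 3 (3.50 log units; beyond the scatter)). All three, however, are changes on an aromatic carbon, so none of them tests a change on this oxygen. For the measured compounds named here, they show only that one change in this set can move the number a long way, and they give no direction for this one. The expectation therefore stays close to compound 2 (55500 nM) with a wide margin on both sides. The estimate means a 1.1-fold lower number from compound 2 to compound 4 (0.05 log units; within the scatter) as the expected step, so no shift beyond the scatter is expected as the central case. Compound 4 is estimated at 50000 nM with a range of 6000 nM to 300000 nM as the expected span.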

Compound 4, half-maximal inhibitory concentration: > 1000000 nM
Compound 4 was reported as a limit; the forecaster's own chance of this, stated with the estimate: 20%; middle value at least 20-fold (1.30 log units) from the limit.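

In this assay, the change from cyclopentyloxy to hydroxy gives an at least 18-fold higher number from compound 2 to compound 4 (1.25 log units; beyond the scatter), and this is the only step shown that is made on the oxygen on the aromatic ring rather than on an aromatic carbon. For the compounds shown here, it gives this position a direction that the earlier steps could not: with fluoro held in place, taking away the cyclopentyl moves the number upward, whereas hydroxy in place of fluoro on an aromatic carbon gives a 180-fold lower number from compound 2 to compound 3 (2.25 log units; beyond the scatter), so a hydroxy group does not read the same way at these two places. The entry for compound 4 is a limit and not a number, so this step gives only a minimum size: the limit of > 1000000 nM in this assay, at which 2 of the 4 values shown sit.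

The compounds shown put only cyclopentyl or hydrogen on this oxygen, which leaves open how a methyl group, a longer chain or a cyclohexyl ring would read there. They also leave open whether taking away the cyclopentyl would carry the same weight in compound 3, with its hydroxy in place of the fluoro of compound 2.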